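4-Chlorophenyl to 4-methoxyphenyl on the shared core

A few compounds are considered here, and "the series" means these few. Any claim that something is new, unique, unknown or untested is made for them only; others in the source may bear on it.

In a functional assay on BT-20 cells (Homo sapiens) for cytotoxicity, read by MTT assay (a lower number here means a stronger inhibitor, a higher number a weaker inhibitor), compound 2 `COc1cc2ncnc(Nc3cc(-c4ccc(Cl)cc4)[nH]n3)c2cc1OC` gives < 100000 nM as a limit of the assay and not a number. Compound 1 `COc1cc2ncnc(Nc3cc(O)[nH]n3)c2cc1OC` gives < 100000 nM as a limit too. Among the measured compounds shown here, the only measured step is a step that the two limits leave unreadable from compound 1 to compound 2 and the evidence is the limit of < 100000 nM in this assay, at which 2 of the 2 values shown sit, alone. Compound 3 `COc1ccc(-c2cc(Nc3ncnc4cc(OC)c(OC)cc34)n[nH]2)cc1` has methoxy in place of chloro on an aromatic carbon, para to a large group (methoxy in place of chloro on an aromatic carbon). No readable step bears on this change, so no shift beyond the scatter is expected in this assay and no direction is favoured. The expected step is a step that the limit leaves unreadable from compound 2 to compound 3 and it stays tentative. Compound 3 is estimated at 30000 nM with an expected range from 5000 nM to 100000 nM in this series.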

Compound 3, half-maximal inhibitory concentration: < 100000 nM
Compound 3: no number, only a limit (the forecaster's own chance of this, stated with the estimate: 75%); the middle value lies beyond the limit too.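

No new step can be read among compound 1, compound 2 and compound 3 in this assay, because all three sit at a limit and give no number: the limit of < 100000 nM in this assay, at which 3 of the 3 values shown sit.

On these data alone, whether hydroxy, 4-chlorophenyl and 4-methoxyphenyl differ at all in this assay stays open.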